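A few compounds are considered here, and "the series" means these few. Any claim that something is new, unique, unknown or untested is made for them only; others in the source may bear on it.

Compound 2 `O=C(CCc1ccc(F)cc1)NNc1c(Cl)cncc1Cl` was tested in a functional assay on HEK293 cells for antagonist activity at P2X purinoceptor 7 (Homo sapiens), read by fluorescence, with a stated time of 2 h (on this read-out lower numbers stand for stronger inhibition and higher numbers for weaker inhibition), and gave 900 nM. Against the other two measured compounds it stands as follows: compound 1 `Cc1cccc(C)c1NNC(=O)CCc1ccccc1` gives 900 nM in this assay, a number level with that of compound 2 at the digits shown and within the scatter, so the two together hold the lowest numbers of the three; compound 3 `O=C(NNc1c(Cl)cncc1Cl)C1Cc2ccccc2C1` gives 4200 nM in this assay, a higher number that lies beyond the scatter and is the furthest from compound 2.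

The next compound, compound 4 `O=C(CCC1CCCC1)NNc1c(Cl)cncc1Cl`, differs from compound 2 in one place: cyclopentyl in place of 4-fluorophenyl on a saturated chain carbon, two bonds along the chain from a carbonyl carbon. No measured pair in this set shows the same exchange of a six-membered aromatic ring of carbon only for a five-membered non-aromatic ring of carbon only, so there is no shown step to lean on. Given that compound 1 with 900 nM and compound 2 with 900 nM sit together despite differing far from this position, the exchange is expected to move the number modestly toward a weaker inhibition, though a result within the scatter would not surprise. Compound 4 is estimated at 1500 nM, with a range from 500 nM to 4500 nM, an expected step of a 1.7-fold higher number from compound 2 to compound 4 (0.22 log units; within the scatter).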

Compound 4, half-maximal inhibitory concentration: 380 nM
Estimate against measurement, compound 4: 3.9-fold (0.60 log units) above; the whole stated range lies above it.
By their numbers in this assay, from the lowest: compound 4; then compounds 1 and 2 (each within the scatter of the next); then compound 3.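

Among these compounds, on a saturated chain carbon, two bonds along the chain from a carbonyl carbon, an aromatic ring is not required for inhibition in this assay: cyclopentyl in place of 4-fluorophenyl gives a 2.4-fold lower number from compound 2 to compound 4 (0.37 log units; beyond the scatter) and is the first change in this set that can be read at this position. The lower number comes with a five-membered non-aromatic ring of carbon only and fewer heavy atoms, so for this pair the larger aromatic group offers no advantage. Nothing at hand explains the difference between these two groups.

As far as these compounds go, whether cyclohexyl, an open butyl chain or a cyclopentyl ring carrying an amine would keep or extend this step remains open. So does whether the same exchange would give a similar step on the core of compound 1.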